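Working notes: compound 1 to compound 4

The source may hold more compounds than are shown below. What is called first, only, known or untested is meant among the compounds shown, and "the series" means these compounds.

Measured so far:
compound 1 `O=C(/C(=C\c1csc([N+](=O)[O-])c1)S(=O)(=O)c1ccc(Br)cc1)c1ccc(Br)cc1` — 1000 nM
compound 2 `O=C(O)c1ccc(C(=O)/C(=C\N2CCN(Cc3ccccc3)C([N+](=O)[O-])C2)SCc2ccc(F)cc2)cc1` — 1000 nM
compound 3 `O=C(/C(=C\c1ccc(O)cc1)SCc1ccc(Cl)c(Cl)c1)c1ccc(Cl)cc1` — 1000 nM

In a functional assay on DU-145 cells (Homo sapiens) for inhibition, read by trypan blue exclusion, with a stated time of 96 h (on this read-out higher numbers stand for weaker inhibition of growth and lower numbers for stronger inhibition of growth), compound 1 gives 1000 nM. Compound 2 gives 1000 nM and compound 3 gives 1000 nM. Compound 1 thus stands level with both at the digits shown; the gaps to compound 2 and to compound 3 lie within the scatter, so no order among the three can be read from this assay.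

Compound 4 `COc1ccc(/C=C(\C(=O)c2ccc(Br)cc2)S(=O)(=O)c2ccc(Br)cc2)c(OC)c1` is not yet measured. It differs from compound 1 by 2,4-dimethoxyphenyl in place of 5-nitrothiophen-3-yl on a double-bonded chain carbon bound to a double-bonded chain carbon. Among the measured compounds shown here, no pair of measured compounds differing in a single place is available, so no measured step guides the direction. The expected step of no change at the digits printed from compound 1 to compound 4 (within the scatter) is none beyond the scatter. Compound 4 is estimated at 1000 nM, within 300 nM to 3000 nM.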

Compound 4, concentration for 50% growth inhibition: 8000 nM
Compound 4: the middle estimate sits 8.0-fold (0.90 log units) below what was measured; measured number outside the range, above it.
By their numbers in this assay, from the lowest: compounds 1, 2 and 3 (each within the scatter of the next); then compound 4.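

This place, on a double-bonded chain carbon bound to a double-bonded chain carbon, is sensitive to the group it carries. In this assay, 2,4-dimethoxyphenyl in place of 5-nitrothiophen-3-yl gives an 8.0-fold higher number from compound 1 to compound 4 (0.90 log units; beyond the scatter) and so weakens inhibition of growth beyond the scatter. No measurement at hand accounts for this step.

The compounds shown leave open whether the step follows the ring or its substituents. An unsubstituted phenyl, a nitrophenyl or a thiophene carrying methoxy would separate these two parts of the change.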